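Amide side chains on a pyrrole-carboxamide series: acid variants

The source may report more compounds than this note shows. Statements on the series, on what has been measured and on what is new or still open speak of the compounds shown alone.

Compounds measured in a functional assay on MCF7 cells (Homo sapiens) for antiproliferative activity, read by MTT assay, with a stated time of 24 h (a lower number here means a stronger inhibitor, a higher number a weaker inhibitor), so far:
compound 1, `CCn1c(C(=O)NCCN)ccc1C(CC)(CC)c1ccc(OCS(=O)(=O)c2ccccc2)c(C)c1`, 6470 nM
compound 2, `CCn1c(C(=O)N[C@@H](C)C(=O)O)ccc1C(CC)(CC)c1ccc(OCS(=O)(=O)c2ccccc2)c(C)c1`, 35500 nM

For the measured compounds named here, compound 2 stands at the higher of the two numbers in this assay; the only step to it, a 5.5-fold higher number from compound 1 to compound 2 (0.74 log units; beyond the scatter), goes beyond the scatter. Compound 3, `CCn1c(C(=O)N[C@@H](CCC(=O)O)C(=O)O)ccc1C(CC)(CC)c1ccc(OCS(=O)(=O)c2ccccc2)c(C)c1`, is not yet measured. Its change from compound 2 is carboxymethyl in place of hydrogen on a saturated chain carbon, two bonds along the chain from an amide-type nitrogen and a carbonyl carbon. Going by the values given here, no measured step covers the same change; the one step at hand, a 5.5-fold higher number from compound 1 to compound 2 (0.74 log units; beyond the scatter), added an acid and weakened inhibition, so a further carboxymethyl is expected to hold the number at or above that of compound 2. Compound 3 is therefore estimated at 50000 nM (range 18000 nM to 150000 nM), an expected step of a 1.4-fold higher number from compound 2 to compound 3 (0.15 log units; within the scatter).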

Compound 3, half-maximal inhibitory concentration: > 50000 nM
Compound 3: only a limit was reported; the forecaster's own chance of this, stated with the estimate: 30%; the middle value lies on the limit itself.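

In this assay compound 3 is reported only as a limit: the limit of > 50000 nM in this assay, at which 1 of the 3 values shown sits. Carboxymethyl on this saturated chain carbon gives an at least 1.4-fold higher number from compound 2 to compound 3 (0.14 log units; that floor lies within the scatter), so the floor does not separate the two acids and the true size of the change cannot be read. 1,3-Dicarboxypropyl in place of 2-aminoethyl gives an at least 7.7-fold higher number from compound 1 to compound 3 (0.88 log units; beyond the scatter), so the added carboxylic acid brings no return toward the number of the amine side chain.

Open, as far as these compounds go, is whether a longer aminoalkyl chain, or a hydroxyl or methyl ester in place of the carboxylic acids, would bring the number down toward that of compound 1.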